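Furan in Place of Methoxyphenyl: What to Expect

This account rests on a few compounds, and the source may have more. Where it says the series, first, only, none or still open, it means among the compounds named here.

Measured compounds:
compound 1 `CC(Br)C(=O)Nc1ccc(C(=O)/C=C/c2ccco2)cc1` – 42%
compound 2 `CC(O[N+](=O)[O-])C(=O)Nc1ccc(C(=O)/C=C/c2ccc(Cl)cc2)cc1` – 62%
compound 3 `COc1ccc(/C=C/C(=O)c2ccc(NC(=O)C(C)O[N+](=O)[O-])cc2)cc1` – 50%

In a functional assay on the whole organism (strain albino) for inhibition, with Rattus norvegicus as the target, read by paw edema, with stated times of 30 min and 3 h, at a dose of 100 mg/kg by the oral route (on this read-out lower numbers stand for less inhibition and higher numbers for more inhibition at the one dose given (going by the name of the read-out)), compound 3 stands second highest of the three numbers. Its nearest neighbour is compound 1, whose value of 42% lies within the scatter of compound 3; the furthest is compound 2, whose 62% is beyond the scatter. Among the measured compounds shown here, the one single-point step that is known, a number 12 percentage points lower from compound 2 to compound 3 (beyond the scatter), is a modest drop.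

Compound 4 `CC(O[N+](=O)[O-])C(=O)Nc1ccc(C(=O)/C=C/c2ccco2)cc1` differs from compound 3 by furan-2-yl in place of 4-methoxyphenyl on a double-bonded chain carbon bound to a double-bonded chain carbon. For the measured compounds named here, no measured pair differs in exactly this way, so no step bears directly on it. Compound 1 also carries furan-2-yl, but it differs from compound 3 in a second place as well; its value and that of compound 3 sit within the scatter of each other. The expected step is therefore a number 4 percentage points lower from compound 3 to compound 4 (within the scatter), a change not beyond the scatter. Compound 4 is estimated at 46% in this assay, with a range from 32% to 60%.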

Compound 4, a percentage reported as inhibition, in the whole organism at one dose (the size of the read-out at that dose, not a potency): 54%
For compound 4 the middle estimate is 8 percentage points below the measured one, within the range that was stated.
By their numbers in this assay, from the lowest: compounds 1, 3, 4 and 2 (each within the scatter of the next, the first and the last beyond it).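

With nitrooxy kept, this assay shows a number 4 percentage points higher from compound 3 to compound 4 (within the scatter) and a number 8 percentage points lower from compound 2 to compound 4 (within the scatter) when furan-2-yl enters on the double-bonded chain carbon. A five-membered aromatic ring therefore gives a number within the scatter of those for both six-membered rings, 4-methoxyphenyl and 4-chlorophenyl, even though those two differ from each other beyond the scatter. With furan-2-yl held fixed, the other changed place also comes into view, as nitrooxy in place of bromo gives a number 12 percentage points higher from compound 1 to compound 4 (beyond the scatter) and no measurement here says what lies behind any of these numbers.

Going by these compounds, whether the change from bromo to nitrooxy gives a similar step with 4-chlorophenyl or 4-methoxyphenyl remains open. So does the outcome with a thiophene ring on the double-bonded chain carbon, or with an amine in place of nitrooxy.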